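The source may hold more compounds than are shown below. What is called first, only, known or untested is meant among the compounds shown, and "the series" means these compounds.

Measured in a functional assay on COLO 205 cells (Homo sapiens) for inhibition, read by sulforhodamine B assay, with a stated time of 48 h, tested at 50 uM; a lower number here means less inhibition of growth, a higher number more inhibition of growth at the concentration tested:
- compound 1 `COc1cc(/C=C/C(=O)/C=C/c2cccc3ccccc23)ccc1OCc1cn(CCCCCOc2cc(=O)oc3ccccc23)nn1`: 40%
- compound 2 `COc1ccccc1/C=C/C(=O)/C=C/c1ccc(OCc2cn(CCCCCOc3cc(=O)oc4ccccc34)nn2)c(OC)c1`: 30%

Going by the values given here, compound 2, at 30%, stands within the scatter of compound 1, at 40%, the only other measured compound in this assay. Compound 3 `COc1cc(/C=C/C(=O)/C=C/c2ccco2)ccc1OCc1cn(CCCCCOc2cc(=O)oc3ccccc23)nn1` has not yet been measured. It differs from compound 2 as follows: furan-2-yl in place of 2-methoxyphenyl on a double-bonded chain carbon bound to a double-bonded chain carbon. In short, furan-2-yl stands in place of 2-methoxyphenyl on a double-bonded chain carbon bound to a double-bonded chain carbon.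

Among the compounds with values here, one measured step bears on this change, as it was made at the same place: a number 10 percentage points lower from compound 1 to compound 2 (within the scatter). That exchange stayed within the scatter. However, it did not involve furan-2-yl, so this single step is only indirect evidence, and the data offer no firm direction for the new change. A step beyond the scatter is therefore not expected, and the estimated step is a number 2 percentage points higher from compound 2 to compound 3 (within the scatter). For compound 3 the estimated value is 32%, with an expected range from 15% to 50%.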

Compound 3, percent growth inhibition at one concentration: 33%
Compound 3: the middle estimate sits 1 percentage points below what was measured, and the stated range covers the measured number.
By their numbers in this assay, from the lowest: compounds 2, 3 and 1 (each within the scatter of the next).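

In this assay, furan-2-yl in place of 2-methoxyphenyl gives a number 3 percentage points higher from compound 2 to compound 3 (within the scatter), and furan-2-yl in place of naphthalen-1-yl gives a number 7 percentage points lower from compound 1 to compound 3 (within the scatter). Before this, only naphthalen-1-yl and 2-methoxyphenyl had stood on this double-bonded chain carbon, so the single earlier step could not show what a smaller group with a hetero atom in its ring would do; furan-2-yl, a five-membered aromatic ring of 5 heavy atoms against the 8 of 2-methoxyphenyl, now shows that this exchange also stays within the scatter, and none of the three groups stands apart from the others in this read-out. Nothing in the data shown accounts for this result.

All three groups at this place are aromatic, so the compounds shown leave open whether a basic amine, a carboxylic acid or a simple saturated chain there would stay within the scatter or move beyond it. They also leave open whether a group such as pyridin-2-yl, with a ring nitrogen in place of the furan oxygen, would separate from these three in this assay.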